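Propyl for Isopropyl on a Shared Core, Measured at a Limit

The source may report more compounds than this note shows. Statements on the series, on what has been measured and on what is new or still open speak of the compounds shown alone.

Of the compounds shown here, three of one series have been tested in a functional assay for inhibition, with Homo sapiens as the target; a higher number here means a weaker inhibitor, a lower number a stronger inhibitor. Compound 1, `CSc1nncc2c(C(C)C)ncn12`, gives only a limit of the assay there, > 48000 nM. Compound 2, `CCCc1ncn2c(SC)nncc12`, also reaches only a limit, > 48000 nM. Compound 3, `Cc1nc(C(C)C)n2c(S)nncc12`, likewise stops at a limit, > 48000 nM.

Compound 1 and compound 2 differ in one place: propyl in place of isopropyl on an aromatic carbon. The measured step is a step that the two limits leave unreadable from compound 1 to compound 2, because of the limit of > 48000 nM in this assay, at which 3 of the 3 values shown sit.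

Compound 4, `CCCc1nc(C)c2cnnc(S)n12`, has not yet been tested. It differs from compound 3 by propyl in place of isopropyl on an aromatic carbon. This is the same kind of change as that from compound 1 to compound 2, though the surroundings differ: in compound 1 the group sits next to the ring nitrogen, two ring bonds from the ring nitrogen, whereas in compound 3 it sits between two ring nitrogen atoms, two ring bonds from the ring atom that bears a methyl group. How the core of compound 3 differs from that of compound 1 is not broken down here.

Going by the values given here, for compound 4 the expected step is a step that the limit leaves unreadable from compound 3 to compound 4, resting on the fact that every value so far sits at the limit, (the limit of > 48000 nM in this assay, at which 3 of the 3 values shown sit). Compound 4 is therefore estimated at 100000 nM, with a likely range from 30000 nM to 400000 nM.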

Compound 4, half-maximal inhibitory concentration: 10000 nM
Compound 4: the middle estimate sits 10-fold (1.00 log units) above what was measured; the measured number lies below the stated range.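

In this assay, putting propyl in place of isopropyl on an aromatic carbon gives an at least 4.8-fold lower number from compound 3 to compound 4 (0.68 log units; beyond the scatter), so on this core the change is linked to a lower number, and the printed size is only a lower bound. The same change on the core of compound 1 gives a step that cannot be read, because the values of both compounds there stop at a limit: the limit of > 48000 nM in this assay, at which 3 of the 4 values shown sit. Going by these compounds alone, the one readable step therefore shows that the change can matter on one core, but it does not show that the gain carries over to the core of compound 1, nor does it show that the gain is absent there.

The compounds shown leave open how a longer chain such as butyl, or an amine, would compare with propyl at this place on the core of compound 4. They also leave open which of the differences between the two cores decides whether the change gives a readable step.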